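Swapping a Pyrrole for a Phenyl on a Kinase Inhibitor

The compounds below may be only part of what the source reports. "The series", "measured", "known", "first", "only" and "open" are said of these compounds alone.

Compound 1 `Cn1c(-n2cccc2)c(C#N)c2c(N)ncnc21`: 239 nM
Compound 2 `C[C@@H]1CCCN1c1c(C#N)c2c(N)nc(N)nc2n1C`: 6 nM

In an assay on isolated protein for binding affinity to Leucine-rich repeat serine/threonine-protein kinase 2 (Homo sapiens), read by TR-FRET and LanthaScreen, with a stated time of 2 h (a lower number here means a stronger inhibitor, a higher number a weaker inhibitor), compound 1 gives 239 nM, the highest of the two numbers measured. For the measured compounds named here, compound 2 gives 6 nM, a far lower number, yet its structure differs from compound 1 in several places, so no single step between them is known. Compound 3 `Cn1c(-c2ccccc2)c(C#N)c2c(N)ncnc21` is not yet measured and differs from compound 1 in one place: phenyl in place of 1H-pyrrol-1-yl on an aromatic carbon. Going by the values given here, with no measured pair isolating this change, the expected step in this assay is a 1.0-fold higher number from compound 1 to compound 3 (0.02 log units; within the scatter), small and likely within the scatter. Compound 3 is therefore estimated at 250 nM, within 80 nM to 800 nM, because compound 1 gives 239 nM.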

Compound 3, inhibition constant: 30 nM
The estimate for compound 3 lay 8.3-fold (0.92 log units) above the measured number; measured number below the stated range.
By their numbers in this assay, from the lowest: compound 2; then compound 3; then compound 1.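

In this assay, this position on the core of compound 1 proves sensitive to the group it carries: phenyl in place of 1H-pyrrol-1-yl gives an 8.0-fold lower number from compound 1 to compound 3 (0.90 log units; beyond the scatter). Both groups are single aromatic rings with no hydrogen-bond donors, yet exchanging one for the other moves the number beyond the scatter. Nothing measured here explains the gain.

Going by these compounds, how a carboxylic acid or a longer alkyl chain would fare at this position remains open. So does the effect of a fluorine atom on the phenyl ring.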